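This account rests on a few compounds, and the source may have more. Where it says the series, first, only, none or still open, it means among the compounds named here.

Values in an ADME assay on L6 cells (Rattus norvegicus) for cytotoxicity, read by resazurin assay, with a stated time of 70 h; on this read-out higher numbers stand for weaker inhibition and lower numbers for stronger inhibition:
- compound 1 `N=C(N)c1ccc2oc(-c3ccc(OCCCOc4ccccc4)cc3)cc2c1`: 7300 nM
- compound 2 `CC(C)NC(=N)c1ccc2oc(-c3ccc(OCCCOc4ccccc4)cc3)cc2c1`: 45600 nM
- compound 3 `c1ccc(OCCCOc2ccc(-c3cc4cc(C5=NCCN5)ccc4o3)cc2)cc1`: 10300 nM

Compound 1 sits at the low end of these numbers, a place it shares within the scatter: a 1.4-fold higher number from compound 1 to compound 3 (0.15 log units; within the scatter). Among the measured compounds shown here, only one step leads clearly away from it: a 6.2-fold higher number from compound 1 to compound 2 (0.80 log units; beyond the scatter).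

Compound 4 `N=C(N)c1ccc2oc(-c3ccc(OCCCCCCOc4ccccc4)cc3)cc2c1` carries a different change: 3-phenoxypropyl in place of phenoxy on a saturated chain carbon, three bonds along the chain from an oxygen on an aromatic ring. It lies on a saturated chain carbon, three bonds along the chain from an oxygen on an aromatic ring. Neither measured step touches this chain, so they give only a general sense of step size in this assay, and no direction. No step beyond the scatter is therefore expected, and the estimated step is a 1.3-fold lower number from compound 1 to compound 4 (0.12 log units; within the scatter). The data contain no chain variation, so the range stays wide. For compound 4 the expected value is 5500 nM, with an estimated range of 2000 nM to 15000 nM.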

Compound 4, half-maximal inhibitory concentration: 3300 nM
Beside the measured number, compound 4's estimate is 1.7-fold (0.22 log units) above it, within the range that was stated.
By their numbers in this assay, from the lowest: compound 4; then compounds 1 and 3 (each within the scatter of the next); then compound 2.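

In this assay, the position on the saturated chain carbon accepts a larger group, with 3-phenoxypropyl in place of phenoxy giving a 2.2-fold lower number from compound 1 to compound 4 (0.34 log units; beyond the scatter) as its step. Neither earlier step from compound 1 led to a lower number, so this is the first change shown to move the series that way beyond the scatter. No measurement here accounts for the step.

From the compounds shown here alone, whether a longer chain or an amine within the chain would shift the number further remains open. So does whether this change would act alike on compound 2 and compound 3.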